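Adding Bromine to the Bare Phenyl Ring

A few compounds are considered here, and "the series" means these few. Any claim that something is new, unique, unknown or untested is made for them only; others in the source may bear on it.

Compound 1 `CN(C)CCn1cnnc1-c1cc(Oc2ccc(NC(=O)N/N=C/c3ccc(Cl)cc3Cl)cc2F)ccn1`: 750 nM
Compound 2 `CN(C)CCn1cnnc1-c1cc(Oc2ccc(NC(=O)N/N=C/c3ccccc3O[N+](=O)[O-])cc2F)ccn1`: 1020 nM
Compound 3 `CN(C)CCn1cnnc1-c1cc(Oc2ccc(NC(=O)N/N=C/c3ccccc3)cc2F)ccn1`: 2730 nM

All three were tested in a functional assay on MKN-45 cells (Homo sapiens) for cytotoxicity, read by MTT assay, with a stated time of 72 h; on this read-out lower numbers stand for stronger inhibition and higher numbers for weaker inhibition. Compound 3 holds the highest number of the three, as the steps of a 3.6-fold higher number from compound 1 to compound 3 (0.56 log units; beyond the scatter) and a 2.7-fold higher number from compound 2 to compound 3 (0.43 log units; beyond the scatter) show; both steps strip a group from the phenyl ring on the carbon double-bonded to nitrogen and both raise the number beyond the scatter. Compound 4 `CN(C)CCn1cnnc1-c1cc(Oc2ccc(NC(=O)N/N=C/c3cccc(Br)c3)cc2F)ccn1` differs from compound 3 by bromo in place of hydrogen on an aromatic carbon, placed meta to a large group. Because a 3.6-fold higher number from compound 1 to compound 3 (0.56 log units; beyond the scatter) and a 2.7-fold higher number from compound 2 to compound 3 (0.43 log units; beyond the scatter) run toward weaker inhibition when substituents leave this ring, putting one back is expected to move the other way, by a modest step of a 2.3-fold lower number from compound 3 to compound 4 (0.36 log units; beyond the scatter) in this assay. Compound 4 is therefore estimated at 1200 nM, within a range of 500 nM to 2900 nM.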

Compound 4, half-maximal inhibitory concentration: 450 nM
Estimate against measurement, compound 4: 2.7-fold (0.43 log units) above; the whole stated range lies above it.
By their numbers in this assay, from the lowest: compounds 4, 1 and 2 (each within the scatter of the next, the first and the last beyond it); then compound 3.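

A single bromo on the bare phenyl ring, placed meta to a large group, has a clear effect in this assay (a 6.1-fold lower number from compound 3 to compound 4 (0.78 log units; beyond the scatter)). That one atom also takes compound 4 past the nitrooxy-bearing compound 2 (a 2.3-fold lower number from compound 2 to compound 4 (0.36 log units; beyond the scatter)). Against the 2,4-dichlorophenyl of compound 1 there is no real separation (a 1.7-fold lower number from compound 1 to compound 4 (0.22 log units; within the scatter)), so one bromine on this ring matches two chlorines here. As far as these compounds go, whether an amine or a carboxylic acid at this place would act like the bromo remains open, as does the effect of the bromo elsewhere on the ring. Nothing available here accounts for the size of this step.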